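Pyrrolidine Nitrogen Substituent in a Cathepsin S Series

The source may report more compounds than this note shows. Statements on the series, on what has been measured and on what is new or still open speak of the compounds shown alone.

Compound 1 `CN1CCC(C#N)(NC(=O)[C@@H](CC(=O)N2CCOCC2)CC2CCCCC2)CC1` gives 251 nM in an assay on isolated protein for inhibition of cathepsin S (Homo sapiens); a lower number here means a stronger inhibitor, a higher number a weaker inhibitor
Compound 2 `N#C[C@@]1(NC(=O)[C@@H](CC(=O)N2CCOCC2)CC2CCCCC2)CCN(C2CCCCC2)C1` gives 23 nM in this assay

Compound 2 has the lowest of the two numbers shown; compound 1 is its nearest neighbor, and the gap between them lies beyond the scatter. Compound 3 `CC(C)N1CC[C@@](C#N)(NC(=O)[C@@H](CC(=O)N2CCOCC2)CC2CCCCC2)C1` differs from compound 2 in one place: isopropyl in place of cyclohexyl on an amine nitrogen in a ring. Going by the values given here, no directly comparable step between measured compounds exists, so the size of the change is uncertain. A modest shift toward a weaker inhibitor is expected, as a 2.6-fold higher number from compound 2 to compound 3 (0.42 log units; beyond the scatter). Compound 3 is therefore estimated at 60 nM in this assay, within a range from 20 nM to 200 nM.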

Compound 3, half-maximal inhibitory concentration: 66 nM
Estimate against measurement, compound 3: 1.1-fold (0.04 log units) below, within the range that was stated.
By their numbers in this assay, from the lowest: compound 2; then compound 3; then compound 1.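

In this assay, the size of the group on this amine nitrogen matters: isopropyl in place of cyclohexyl gives a measurable loss (a 2.9-fold higher number from compound 2 to compound 3 (0.46 log units; beyond the scatter)). Even so, the six-membered carbon ring is not required for a stronger inhibitor than compound 1, since 3-cyano-1-isopropylpyrrolidin-3-yl in place of 4-cyano-1-methylpiperidin-4-yl still gives an improvement (a 3.8-fold lower number from compound 1 to compound 3 (0.58 log units; beyond the scatter)). No measurement shown accounts for either step.

Going by these compounds, that second step changes the ring and the nitrogen substituent together, so the share of each remains open. On these data alone, how methyl, cyclopentyl or benzyl on this nitrogen would compare also remains open.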